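A Propargyl Amide Gives Way to an Acid-Bearing Amide

The source may report more compounds than this note shows. Statements on the series, on what has been measured and on what is new or still open speak of the compounds shown alone.

In a functional assay on MCF7 cells (Homo sapiens), read by MTT assay, with a stated time of 48 h (on this read-out higher numbers stand for weaker inhibition and lower numbers for stronger inhibition), compound 1, `C#CCNC(=O)c1ccc(C(CC)(CC)c2ccc(OCC(O)C(C)(C)C)c(C)c2)n1CC`, gives only a limit, > 50000 nM, and that value sits at the limit of > 50000 nM in this assay, at which 1 of the 2 values shown sits. Compound 2, `CC[C@@H](C)[C@H](NC(=O)c1ccc(C(CC)(CC)c2ccc(OCC(=O)C(C)(C)C)c(C)c2)n1CC)C(=O)O`, gives 160 nM in this assay. Compound 3, `CCn1c(C(=O)N(C)CC(=O)O)ccc1C(CC)(CC)c1ccc(OCC(O)C(C)(C)C)c(C)c1`, differs from compound 1 by (carboxymethyl)(methyl)amino in place of propargylamino on a carbonyl carbon. For the measured compounds named here, since compound 1 stands at a limit, no measured step starts from it. The step of an at least 20-fold lower number from compound 1 to compound 3 (1.30 log units; beyond the scatter) is expected to run toward stronger inhibition, beyond the usual scatter. Compound 3 is accordingly estimated at 2500 nM, with a range from 300 nM to 25000 nM.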

Compound 3, half-maximal inhibitory concentration: 25400 nM
Compound 3: middle estimate off by 10-fold (1.01 log units), on the low side; measured number above the stated range.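

In this assay compound 3 gives a number that can be read, 25400 nM, with (carboxymethyl)(methyl)amino on the carbonyl carbon. The change reads as an at least 1.9-fold lower number from compound 1 to compound 3 (0.29 log units; that floor lies within the scatter), so it supplies a floor rather than a size. The true size of the step stays unknown because compound 1 stands at a limit of the assay: the limit of > 50000 nM in this assay, at which 1 of the 3 values shown sits.

Whether the carboxylic acid or the methyl group of the new amide accounts for the change remains open. So does how an amine or a longer chain ending in a carboxylic acid would read on this carbonyl carbon.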